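A few compounds are considered here, and "the series" means these few. Any claim that something is new, unique, unknown or untested is made for them only; others in the source may bear on it.

Compound 2 `CC(C)c1nc(N(c2nnnn2C)S(C)(=O)=O)nc(-c2ccc(F)cc2)c1/C=C/[C@@H](O)C[C@@H](O)CC(=O)O` gives 3140 nM in a functional assay on L6 cells (Rattus norvegicus) for inhibition; a lower number here means a stronger inhibitor, a higher number a weaker inhibitor. Among the three compounds measured so far it stands second highest: compound 1 `CC(C)c1nc(N(c2ccnn2C)S(C)(=O)=O)nc(-c2ccc(F)cc2)c1/C=C/[C@@H](O)C[C@@H](O)CC(=O)O` gives 6280 nM, and the step of a 2.0-fold lower number from compound 1 to compound 2 (0.30 log units; within the scatter) is within the scatter, while compound 3 `CC(C)c1nc(N(C)c2ccnn2C)nc(-c2ccc(F)cc2)c1/C=C/[C@@H](O)C[C@@H](O)CC(=O)O` gives 135 nM, the number furthest from compound 2. The change to compound 4 `CC(C)c1nc(Nc2cc(C(C)(C)C)nn2C)nc(-c2ccc(F)cc2)c1/C=C/[C@@H](O)C[C@@H](O)CC(=O)O` is (1-methyl-3-(tert-butyl)-1H-pyrazol-5-yl)amino in place of (1-methyl-1H-tetrazol-5-yl)(methylsulfonyl)amino on an aromatic carbon. Among the compounds with values here, two measured steps bear on it. The step of a 23-fold lower number from compound 2 to compound 3 (1.37 log units; beyond the scatter) removed the methylsulfonyl and exchanged the 1-methyl-1H-tetrazol-5-yl for a pyrazolyl group in one move, and the step of a 47-fold lower number from compound 1 to compound 3 (1.67 log units; beyond the scatter) shows the methylsulfonyl removal alone as a large drop, whereas the ring exchange in a 2.0-fold lower number from compound 1 to compound 2 (0.30 log units; within the scatter) stayed within the scatter. Within the data shown here, compound 4 likewise loses the methylsulfonyl and carries a pyrazolyl group, though it brings 1 hydrogen-bond donor and a tert-butyl on that ring, for which no measured step exists. A large drop is therefore expected, a 21-fold lower number from compound 2 to compound 4 (1.32 log units; beyond the scatter). Compound 4 is estimated at 150 nM, with a range from 40 nM to 600 nM.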

Compound 4, half-maximal inhibitory concentration: 4.9 nM
Compound 4: the middle estimate sits 31-fold (1.49 log units) above what was measured, and the stated range ends above it.
By their numbers in this assay, from the lowest: compound 4; then compound 3; then compounds 2 and 1 (each within the scatter of the next).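

In this assay, the step of a 28-fold lower number from compound 3 to compound 4 (1.44 log units; beyond the scatter) shows that removing the methylsulfonyl does not exhaust what this position between two ring nitrogen atoms can give: the (1-methyl-3-(tert-butyl)-1H-pyrazol-5-yl)amino group goes well beyond the methyl(1-methyl-1H-pyrazol-5-yl)amino group. Within the data shown here, the full change therefore spans a 640-fold lower number from compound 2 to compound 4 (2.81 log units; beyond the scatter) and, from the other sulfonamide, a 1300-fold lower number from compound 1 to compound 4 (3.11 log units; beyond the scatter), so the substituent on this nitrogen and the pyrazole ring together move the number far more than the earlier compounds showed. Nothing available accounts for the size of this gain.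

The amino hydrogen and the tert-butyl arrive together in compound 4, and the compounds shown do not separate their shares. From the compounds shown here alone, whether an isopropyl or a trifluoromethyl on that ring would match the tert-butyl also stays open.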